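A few compounds are considered here, and "the series" means these few. Any claim that something is new, unique, unknown or untested is made for them only; others in the source may bear on it.

Measured compounds:
- compound 1 `c1coc(-c2ccccc2NCC2=NCCN2)c1`: 0.468 nM
- compound 2 `c1cnc(-c2ccccc2NCC2=NCCN2)nc1`: 10 nM

For the measured compounds named here, in a functional assay for activation of Alpha-1A adrenergic receptor (Homo sapiens), read by calcium flux (on this read-out higher numbers stand for an effect only at larger amounts of compound and lower numbers for an effect already at smaller amounts), compound 2 gives the higher of the two numbers known so far; the only neighbour is compound 1, and the step of a 21-fold higher number from compound 1 to compound 2 (1.33 log units; beyond the scatter) is the single change on which anything can be judged.

Compound 3 `CO/N=C(\C)c1ccccc1NCC1=NCCN1` is not yet measured. It differs from compound 2 by a group of 5 heavy atoms (3 carbon, 1 nitrogen, 1 oxygen; no ring) in place of a group of 6 heavy atoms (4 carbon, 2 nitrogen; one six-membered aromatic ring with 2 hetero atoms), on an aromatic carbon, the new group sitting on an aromatic carbon of a six-membered aromatic ring of carbon only. Going by the values given here, no measured step covers this exchange itself. What bears on it is only that the same position has already been varied once, and that step, from furan-2-yl to pyrimidin-2-yl, was large. The position is therefore sensitive, but the direction for a group with no ring and one double bond outside aromatic rings cannot be read from compounds 1 and 2.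

For compound 3 in this assay the number is expected near that of compound 2, as a 1.3-fold lower number from compound 2 to compound 3 (0.10 log units; within the scatter), with wide uncertainty: estimate 8 nM, range 1.5 nM to 50 nM.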

Compound 3, half-maximal effective concentration: 20.9 nM
The estimate for compound 3 lay 2.6-fold (0.42 log units) below the measured number, within the range that was stated.
By their numbers in this assay, from the lowest: compound 1; then compound 2; then compound 3.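

In this assay, a group with no ring at this place on the six-membered aromatic ring of carbon only gives a 2.1-fold higher number from compound 2 to compound 3 (0.32 log units; beyond the scatter), a modest step that is still beyond the scatter, so among these compounds a ring in the substituent is not needed for a number close to that of compound 2. The low number of compound 1 now stands apart from both other groups, with a 45-fold higher number from compound 1 to compound 3 (1.65 log units; beyond the scatter) as the largest step in the set, and the ringless group of compound 3 and the pyrimidin-2-yl of compound 2 both end far above it, so the presence of an aromatic ring alone does not separate compound 1 from the others. Nothing available on these compounds accounts for the sizes of these steps.

As far as these compounds go, whether the low number belongs to furan-2-yl alone or is shared by other five-membered aromatic rings, such as thiophen-2-yl or pyrrol-2-yl, remains open. Also open, from the compounds shown here alone, is how a primary amine, a carboxylic acid or a longer chain on the oxygen of the entering group would read at this same place, and whether the geometry of its double bond matters.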